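Replacing the benzyl ester of compound 3 with a carbamate chain

A few compounds are considered here, and "the series" means these few. Any claim that something is new, unique, unknown or untested is made for them only; others in the source may bear on it.

Of the compounds shown here, three sharing one core have been tested in a functional assay on the whole organism (Tail, strain ICR) with Mus musculus as the target, in the tail flick test, with a stated time of 120 min, at a dose of 25 umol/kg by the oral route; a lower number here means a weaker effect, a higher number a stronger effect of the compound at the dose given. Compound 1, `C[C@@H](O)[C@H](NC(=O)CN(c1ncnc2c1ncn2C1CCCCO1)C1CC1)C(=O)OCc1ccccc1`, gives 10.9%. Compound 2, `O=C(CN(c1ncnc2c1ncn2C1CCCCO1)C1CC1)N[C@@H](CO)C(=O)OCc1ccccc1`, gives 29.2%. Among the measured compounds shown here, compound 3, `O=C(CN(c1ncnc2c1ncn2C1CCCCO1)C1CC1)N[C@@H](CC(=O)OCc1ccccc1)C(=O)OCc1ccccc1`, gives 7.82%, the lowest of the three numbers, although its gap to compound 1 is within the scatter; only the step of a number 21.4 percentage points lower from compound 2 to compound 3 (beyond the scatter) is beyond it.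

Compound 4, `CC(C)(C)OC(=O)NCCCC[C@H](NC(=O)CN(c1ncnc2c1ncn2C1CCCCO1)C1CC1)C(=O)OCc1ccccc1`, has not yet been measured. It differs from compound 3 by 3-((tert-butoxycarbonyl)amino)propyl in place of benzyloxycarbonyl on a saturated chain carbon, two bonds along the chain from an amide-type nitrogen and a carbonyl carbon.

For the measured compounds named here, the steps that bear on this change are those at the same place: the hydroxy-to-benzyloxycarbonyl step a number 21.4 percentage points lower from compound 2 to compound 3 (beyond the scatter) and the step of a number 3.1 percentage points lower from compound 1 to compound 3 (within the scatter). The hydroxy group of compound 2 thus goes with the strongest number, while the two larger groups of compound 1 and compound 3 sit close together. The entering group is again large, but it carries a hydrogen-bond donor as the hydroxy of compound 2 does, so a small rise is expected rather than none: a number 5.2 percentage points higher from compound 3 to compound 4 (within the scatter). Compound 4 is estimated to give 13%, within 3% to 28%.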

Compound 4, a percentage reported as activity, at one dose (the size of the read-out at that dose, not a potency): 28.4%
Compound 4: the middle estimate sits 15.4 percentage points below what was measured, and the stated range ends below it.
By their numbers in this assay, from the lowest: compounds 3 and 1 (each within the scatter of the next); then compounds 4 and 2 (each within the scatter of the next).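

At this place in this assay, the step of a number 20.6 percentage points higher from compound 3 to compound 4 (beyond the scatter) shows that a large side group does not by itself keep the number low, and the step of a number 17.5 percentage points higher from compound 1 to compound 4 (beyond the scatter) points the same way. The long chain also stands level with the small hydroxy, as the step of a number 0.8 percentage points lower from compound 2 to compound 4 (within the scatter) marks no real difference, so two very different groups now share the upper end of this series. The entering group has no ring and one hydrogen-bond donor where benzyloxycarbonyl has an aromatic ring and none, yet nothing shown gives a reason for the rise.

As far as these compounds go, whether the lost ring, the added donor or the tert-butoxycarbonyl cap goes with the rise stays open. A free amine at the end of the same chain, or a plain butyl chain without the carbamate, would help to separate these.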